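Swapping a phenyl for a methyl on a dicyano-amine core

A few compounds are considered here, and "the series" means these few. Any claim that something is new, unique, unknown or untested is made for them only; others in the source may bear on it.

Of the compounds shown here, three of one family have been tested in an assay on isolated protein for inhibition of glucose-6-phosphatase catalytic subunit 1 (Homo sapiens), tested at 100 uM; a lower number here means less inhibition, a higher number more inhibition at the concentration tested (going by the name of the read-out). Compound 1 `CSc1c(C#N)c(N)c(C#N)c(-c2ccccc2)c1-c1ccccc1` gives 7.4% in this assay. Compound 2 `COc1ccc(-c2c(C#N)c(N)c(C#N)c(SC)c2-c2ccccc2)cc1` differs from compound 1 only by a methoxy in place of hydrogen on an aromatic carbon. In this assay compound 2 gives 6.8%; the step of a number 0.6 percentage points lower from compound 1 to compound 2 (within the scatter) is within the scatter. Compound 3 `CSc1c(C#N)c(N)c(C#N)c(C)c1-c1ccc(C(F)(F)F)cc1`, which carries a methyl and a trifluoromethyl-substituted ring on the shared core, gives 14.4%. Compound 2 has the lowest of the three numbers, but its distances to compound 1 and to compound 3 both lie within the scatter, so the three values are not distinguishable.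

Compound 4 `COc1ccc(-c2c(C)c(SC)c(C#N)c(N)c2C#N)cc1` has not yet been measured. It differs from compound 2 in one place: methyl in place of phenyl on an aromatic carbon. Among the measured compounds shown here, no measured step matches this change exactly. For the measured compounds named here, the only measured step, from compound 1 to compound 2, concerns a different group and is within the scatter, and compound 3, the one measured compound that also bears a methyl on the shared core, gives a value within the scatter of compound 2. Compound 4 is therefore expected to give a step of a number 2.2 percentage points higher from compound 2 to compound 4 (within the scatter) that stays within the scatter. The estimate for compound 4 is 9%, with a range from 0% to 20%.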

Compound 4, a percentage reported as inhibition, at one concentration (the size of the read-out at that concentration, not a potency): 12.3%
Beside the measured number, compound 4's estimate is 3.3 percentage points below it; the range from low to high includes it.
By their numbers in this assay, from the lowest: compounds 2, 1, 4 and 3 (each within the scatter of the next).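

At this position, on an aromatic carbon para to an amino group, methyl in place of phenyl removes a six-membered aromatic ring of carbon only and leaves 1 heavy atom where 6 stood, and this assay records a number 5.5 percentage points higher from compound 2 to compound 4 (within the scatter) for this change. Among the compounds shown here, this is the first measured step at this position, and it shows that even this large a change in the size of the group gives a number that cannot be told apart from that of compound 2. Nothing measured alongside these compounds accounts for the size of this step.

On these data alone, whether a different group at this position, such as a primary amine, a carboxylic acid or a longer chain like propyl, would give a number beyond the scatter remains open, since only phenyl and methyl can be compared here. The read-out is also taken at one concentration and is not a potency, so the compounds shown leave open whether compound 2 and compound 4 would differ across a range of concentrations.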